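The compounds below may be only part of what the source reports. "The series", "measured", "known", "first", "only" and "open" are said of these compounds alone.

Compound 1, `Cc1ccc(NN=C(c2nc3ccccc3[nH]2)c2nc3ccccc3[nH]2)cc1`: 239000 nM
Compound 2, `COc1ccc(NN=C(c2nc3ccccc3[nH]2)c2nc3ccccc3[nH]2)cc1`: 235000 nM

Of the compounds shown here, two have been tested so far. In a functional assay on K562 cells (Homo sapiens) for cytotoxicity, read by MTT assay, with a stated time of 72 h (on this read-out lower numbers stand for stronger inhibition and higher numbers for weaker inhibition), compound 1 gives 239000 nM, and compound 2 gives 235000 nM. The two share the same core and differ only in the group carried on the outer benzene ring; that change gave a 1.0-fold lower number from compound 1 to compound 2 (0.01 log units; within the scatter), so the two numbers lie within the usual scatter of one another and neither compound can be said to stand apart from the other.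

Compound 3, `O=[N+]([O-])c1ccc(NN=C(c2nc3ccccc3[nH]2)c2nc3ccccc3[nH]2)cc1`, is not yet measured. It differs from compound 2 in that (nitro in place of methoxy on an aromatic carbon). Among the measured compounds shown here, the only measured step that bears on this one is the swap at the same ring carbon, which gave a 1.0-fold lower number from compound 1 to compound 2 (0.01 log units; within the scatter); that step, however, did not involve a nitro group, so no measured step speaks directly to the change in hand. For the measured compounds named here, with the single step at this place lying within the scatter, compound 3 is expected to give 200000 nM, with a likely range from 70000 nM to 600000 nM, which means an estimated 1.2-fold lower number from compound 2 to compound 3 (0.07 log units; within the scatter).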

Compound 3, half-maximal inhibitory concentration: 101000 nM
The estimate for compound 3 lay 2.0-fold (0.30 log units) above the measured number; the range from low to high includes it.
By their numbers in this assay, from the lowest: compound 3; then compounds 2 and 1 (each within the scatter of the next).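

The earlier swap of methyl for methoxy on this ring carbon left the number within the scatter, so the position could have seemed indifferent to what it carries. Nitro shows that it is not: in this assay, nitro in place of methoxy gives a 2.3-fold lower number from compound 2 to compound 3 (0.37 log units; beyond the scatter), and nitro in place of methyl gives a 2.4-fold lower number from compound 1 to compound 3 (0.37 log units; beyond the scatter). Both steps are modest but beyond the scatter, so compound 3 stands apart from the other two, and the group at this position can shift the number, though with compound 3 at 101000 nM the shift so far is small; nothing available here explains why nitro differs from the other two groups.

Among the compounds shown here, with only three groups at this one ring carbon, it remains open whether nitro is a special case or part of a wider trend, and an amine, a carboxylic acid or a chlorine atom in the same place would help to settle this. Also open, going by these compounds, is whether nitro would give a similar step at another carbon of the ring, or with changes to the shared core.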